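The source may report more compounds than this note shows. Statements on the series, on what has been measured and on what is new or still open speak of the compounds shown alone.

In an assay on microsomes for inhibition of acyl-CoA:cholesterol acyltransferase (Oryctolagus cuniculus) (a lower number here means a stronger inhibitor, a higher number a weaker inhibitor), three compounds have been measured so far:

compound 1 `CC(C)c1ccc(C2(CNC(=O)Nc3c(C(C)C)cccc3C(C)C)CCCC2)cc1`, 48 nM
compound 2 `COc1cccc(C2(CNC(=O)Nc3c(C(C)C)cccc3C(C)C)CCCC2)c1`, 13 nM
compound 3 `CC(C)c1cccc(C(C)C)c1NC(=O)NCC1(c2ccc(N)cc2)CCCC1`, 29 nM

Compound 3 stands second highest of the three numbers, close to compound 1, as a 1.7-fold lower number from compound 1 to compound 3 (0.22 log units; within the scatter) lies within the scatter, while a 2.2-fold higher number from compound 2 to compound 3 (0.35 log units; beyond the scatter) lies beyond it. Compound 4 `COC(=O)c1cccc(C2(CNC(=O)Nc3c(C(C)C)cccc3C(C)C)CCCC2)c1` carries 3-(methoxycarbonyl)phenyl in place of 4-aminophenyl on a saturated ring carbon. Two measured steps exchange the aryl group on that same saturated ring carbon: a 3.7-fold lower number from compound 1 to compound 2 (0.57 log units; beyond the scatter) and a 2.2-fold higher number from compound 2 to compound 3 (0.35 log units; beyond the scatter), both modest. The change to compound 4 is of the same kind, so a modest step is expected in this assay, more likely towards a lower number, since compound 2 with its 3-methoxyphenyl gives 13 nM. Compound 4 is therefore estimated at 20 nM, within 8 nM to 50 nM, which means an expected step of a 1.5-fold lower number from compound 3 to compound 4 (0.16 log units; within the scatter).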

Compound 4, half-maximal inhibitory concentration: 34 nM
Estimate against measurement, compound 4: 1.7-fold (0.23 log units) below; the range from low to high includes it.
By their numbers in this assay, from the lowest: compound 2; then compounds 3, 4 and 1 (each within the scatter of the next).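

In this assay, 3-(methoxycarbonyl)phenyl and 4-aminophenyl on the saturated ring carbon cannot be told apart (a 1.2-fold higher number from compound 3 to compound 4 (0.07 log units; within the scatter)), nor can it be told from 4-isopropylphenyl (a 1.4-fold lower number from compound 1 to compound 4 (0.15 log units; within the scatter)). Methoxycarbonyl in place of methoxy on an aromatic carbon does separate two compounds (a 2.6-fold higher number from compound 2 to compound 4 (0.42 log units; beyond the scatter)), so compound 2 alone stands apart among the four. Nothing available bears on why. Open, as far as these compounds go, is whether a carboxylic acid in place of the methoxycarbonyl, or an ethoxy group in place of the methoxy, would stay with compound 2 or join the other three.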